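The compounds below may be only part of what the source reports. "The series", "measured", "known", "first", "only" and "open" are said of these compounds alone.

Working notes on the series. Within the data shown here, compound 2 `CC(C)(C)/N=c1\c(O)c(O)\c1=N/c1cccnc1` has been measured in a functional assay for inhibition, with Rattus norvegicus as the target (a higher number here means a weaker inhibitor, a lower number a stronger inhibitor), and gives 2800 nM; of the two numbers recorded so far it sits at the top, though its only neighbour, compound 1 `C[C@@H](/N=c1\c(O)c(O)\c1=N/c1cccnc1)C(C)(C)C` at 1900 nM, is not separated from it beyond the scatter. Among the measured compounds shown here, the one measured step so far, a 1.5-fold higher number from compound 1 to compound 2 (0.17 log units; within the scatter), is within the scatter. Compound 3 `CCC/N=c1\c(O)c(O)\c1=N/c1cccnc1` is the next member and has not been measured. It differs from compound 2 in one place: propyl in place of tert-butyl on a double-bonded nitrogen. For the measured compounds named here, the only measured step that bears on this change is the one already noted, which also exchanged the group on the double-bonded nitrogen and showed no movement beyond the scatter. Going by the values given here, no measured step contrasts a branched with an unbranched group at this position, so the basis for expecting a change is thin. The expected step in this assay is therefore no change at the digits printed from compound 2 to compound 3 (within the scatter), nothing beyond the scatter. Compound 3 is estimated at 2800 nM, with a range from 900 nM to 8500 nM.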

Compound 3, half-maximal inhibitory concentration: > 30000 nM
Compound 3: a limit, no number; the forecaster's own chance of this, stated with the estimate: 5%; at least 10-fold (1.02 log units) between middle value and limit.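

Compound 3 stands at a limit of the assay and has no number in this assay: the limit of > 30000 nM in this assay, at which 1 of the 3 values shown sits. The group on the double-bonded nitrogen is not indifferent after all: propyl in place of tert-butyl gives an at least 10-fold higher number from compound 2 to compound 3 (1.02 log units; beyond the scatter), and propyl in place of 1,2,2-trimethylpropyl gives an at least 15-fold higher number from compound 1 to compound 3 (1.19 log units; beyond the scatter), both far larger than the earlier step between the two branched groups, a 1.5-fold higher number from compound 1 to compound 2 (0.17 log units; within the scatter). Across these three compounds, the two branched groups stay within the scatter of each other and the unbranched propyl alone parts from them, with no compound shown going against that reading, though it rests on a single unbranched example.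

From the compounds shown here alone, the limit fixes only one side of both new steps, so the true size of the loss on going to propyl stays open. Also open, going by these compounds, is whether branching itself is what separates these compounds, or whether the result is particular to propyl; isopropyl, a longer chain such as pentyl or a ring such as cyclohexyl on the double-bonded nitrogen would bear on that question.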